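A few compounds are considered here, and "the series" means these few. Any claim that something is new, unique, unknown or untested is made for them only; others in the source may bear on it.

Within the data shown here, compound 1 `CN(C)Cc1ccc(-c2cnc(N)c(C(=O)NC[C@@](C)(O)C(F)(F)F)n2)cc1` gives 510000 nM in a physicochemical assay for solubility, at pH 6.8 (a higher number here means a more soluble compound, a lower number a less soluble compound), and that is the only plain number in this set. Compound 2 `CCN(CC)Cc1ccc(-c2cnc(N)c(C(=O)NC[C@@](C)(O)C(F)(F)F)n2)cc1` sits at a limit of the assay rather than at a number: in this assay compound 2 reads > 1000000 nM (the limit of > 1000000 nM in this assay, at which 1 of the 2 values shown sits). The step of an at least 1.9-fold higher number from compound 1 to compound 2 (0.29 log units; that floor lies within the scatter) alters a different part of the molecule. Among the measured compounds shown here, compound 3 `CN(C)Cc1ccc(-c2cnc(N)c(C(=O)NC3CCCCC3)n2)cc1` differs from compound 1 by cyclohexyl in place of 2-hydroxy-2-(trifluoromethyl)propyl on an amide-type nitrogen, and no measured step here covers that change, so the basis for an expectation is thin. For compound 3 the estimated value in this assay is 150000 nM, with a wide range from 30000 nM to 600000 nM. The expected step is a 3.4-fold lower number from compound 1 to compound 3 (0.53 log units; beyond the scatter), a move toward a lower number.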

Compound 3, solubility: 190000 nM
The estimate for compound 3 lay 1.3-fold (0.10 log units) below the measured number; measured number inside the range.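

Compound 1 and compound 2 share the group on the amide-type nitrogen, while compound 3 shows that this position also counts in this assay: cyclohexyl in place of 2-hydroxy-2-(trifluoromethyl)propyl gives a 2.7-fold lower number from compound 1 to compound 3 (0.43 log units; beyond the scatter). This swap replaces a ringless chain carrying hydroxyl and trifluoromethyl with an all-carbon ring, so no single feature can be singled out. Nothing shown here accounts for the change. Open, on these data alone, is whether a cyclohexyl carrying a hydroxyl, or a plain 2-hydroxypropyl chain without trifluoromethyl, would read closer to compound 1. Also open, as far as these compounds go, is how cyclohexyl behaves alongside the diethylamino group of compound 2.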